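Adding a second hydroxy to compound 3

A few compounds are considered here, and "the series" means these few. Any claim that something is new, unique, unknown or untested is made for them only; others in the source may bear on it.

Measured so far in a functional assay on A549 cells (Homo sapiens) for inhibition, read by MTT assay, with a stated time of 72 h; a higher number here means a weaker inhibitor, a lower number a stronger inhibitor
Compound 1 `COc1ccccc1/C=C/C(=O)c1c(OC)cc(O)c(CC=C(C)C)c1O` gives 12500 nM
Compound 2 `COc1cc(O)c(CC=C(C)C)c(O)c1C(=O)/C=C/c1ccc(C(F)(F)F)cc1` gives 11100 nM
Compound 3 `COc1cc(OC)c(C(=O)/C=C/c2ccc(O)cc2)c(OC)c1` gives 49400 nM

Among these three, compound 3 stands highest at 49400 nM in this assay and is therefore the weakest inhibitor here. Compound 1 and compound 2 both lie lower by more than the usual scatter of repeat measurements. Among the compounds with values here, these three compounds differ from one another in more than one place, so they offer no clean example of what a single change does.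

Compound 4 (`COc1cc(OC)c(C(=O)/C=C/c2ccc(O)c(O)c2)c(OC)c1`) has not yet been measured. It differs from compound 3 in one place only: hydroxy in place of hydrogen on an aromatic carbon. This is hydroxy in place of hydrogen on an aromatic carbon, ortho to a hydroxy group, and it turns 4-hydroxyphenyl into 3,4-dihydroxyphenyl.

Within the data shown here, with no measured step of this kind to go on, any forecast is loose. Compound 1 at 12500 nM shows that a lower number is reachable in this small set, so a modest move downward, somewhat beyond the scatter, is expected. The expected change is a 2.5-fold lower number from compound 3 to compound 4 (0.39 log units; beyond the scatter) and it carries wide uncertainty. For compound 4 the estimated value is 20000 nM, with an expected range of 7000 nM to 50000 nM in repeat measurements.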

Compound 4, half-maximal inhibitory concentration: 8200 nM
For compound 4 the middle estimate is 2.4-fold (0.39 log units) above the measured one, within the range that was stated.
By their numbers in this assay, from the lowest: compounds 4, 2 and 1 (each within the scatter of the next); then compound 3.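

In this assay, a hydroxy on the aromatic carbon ortho to a hydroxy group, turning 4-hydroxyphenyl into 3,4-dihydroxyphenyl, gives a 6.0-fold lower number from compound 3 to compound 4 (0.78 log units; beyond the scatter) and so a change larger than the usual scatter. Within the data shown here, this is the first change in the set that sits in one place only, so a shift in the number can now be tied to a single added group rather than to several differences at once. It shows that this aromatic carbon can carry a hydroxy without loss in this cell assay, and that the number falls when it does, though no measurement shown here says why.

On these data alone, what remains open is whether the hydroxy itself matters at this carbon or whether any added group would do, and a methoxy, a fluorine or an amine in the same place would help to separate those two readings. As far as these compounds go, it is also open whether the same added hydroxy would lower the number by a similar amount in compound 1 or compound 2, whose other parts differ from those of compound 3.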